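Benzyl thioether series: cyano in place of trifluoromethyl

The source may report more compounds than this note shows. Statements on the series, on what has been measured and on what is new or still open speak of the compounds shown alone.

Compound 1 `Cc1cc(=O)oc2cc(Sc3cccc(Cl)n3)ccc12` carries its aryl group directly on the sulfur, compound 2 `Cc1cc(=O)oc2cc(SCc3cccc(C(F)(F)F)c3)ccc12` through a benzyl link. In a functional assay on KBVIN cells (Homo sapiens) for antiproliferative activity, read by sulforhodamine B assay, with a stated time of 72 h (on this read-out higher numbers stand for weaker inhibition of growth and lower numbers for stronger inhibition of growth), compound 1 gives 920 nM. Compound 2 gives only a limit, > 28500 nM, and not a number. Compound 2 therefore stands at the limit of > 28500 nM in this assay, at which 1 of the 2 values shown sits, and the two compounds differ in more than one place, so their values show no more than that compound 1 is measured and compound 2 lies beyond range. Compound 3 `Cc1cc(=O)oc2cc(SCc3cccc(C#N)c3)ccc12` follows from compound 2 by cyano in place of trifluoromethyl on an aromatic carbon. Among the measured compounds shown here, no measured step between close neighbours exists to guide this change. Starting from a limit, the step of an at least 1.1-fold lower number from compound 2 to compound 3 (0.05 log units; that floor lies within the scatter) is expected to be small, with compound 3 likely to remain weak. Compound 3 is estimated at 25000 nM in this assay, between 8000 nM and 60000 nM.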

Compound 3, concentration for 50% growth inhibition: > 32500 nM
Compound 3 gave a limit, no number; the forecaster's own chance of this, stated with the estimate: 55%; middle value at least 1.3-fold (0.11 log units) away from the limit.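

In this assay, compound 2 and compound 3 each give only a limit and not a number, so no step can be read between them. The compounds shown leave open whether cyano in place of trifluoromethyl changes growth inhibition at all when the aryl group sits on a benzyl link.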